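Compound 2 to compound 4: an expected step

The compounds below may be only part of what the source reports. "The series", "measured", "known", "first", "only" and "open" are said of these compounds alone.

Measured so far:
- compound 1 `O=C(NCc1cc(Cl)ccc1-n1cnnn1)[C@@H]1C[C@@H]2C[C@@H]2N1C(=O)[C@H](O)CC1CC1`: 3.6 10^-6 cm/s
- compound 2 `O=C(NCc1cc(Cl)ccc1-n1cnnn1)[C@@H]1[C@@H]2C[C@@H]2CN1C(=O)[C@H](O)Cc1ccccn1`: 0.62 10^-6 cm/s
- compound 3 `CC(C)CC[C@@H](O)C(=O)N1N=CC[C@H]1C(=O)NCc1cc(Cl)ccc1-n1cnnn1`: 29 10^-6 cm/s

In an ADME assay on Caco-2 cells (Homo sapiens) for permeability, read by LC-MS, in the apical to basolateral direction, with a stated time of 60 min, at pH 6.5 (on this read-out lower numbers stand for lower permeability and higher numbers for higher permeability), compound 2 gives 0.62 10^-6 cm/s, the lowest of the three numbers, and its gaps to compound 1 and compound 3 both lie beyond the scatter. Compound 4 `O=C(NCc1cc(Cl)ccc1-n1cnnn1)[C@@H]1[C@@H]2C[C@@H]2CN1C(=O)[C@H](O)c1ccccc1F` is not yet measured. It differs from compound 2 as follows: 2-fluorophenyl in place of (pyridin-2-yl)methyl on a saturated chain carbon bound to a carbonyl carbon and an oxygen on a saturated carbon. Going by the values given here, no measured pair isolates this change, so the expectation is loose. Compound 2 sits at the bottom of the range at 0.62 10^-6 cm/s, and compound 1 gives 3.6 10^-6 cm/s, so a rise beyond the scatter is expected in this assay. The expected size is a 4.8-fold higher number from compound 2 to compound 4 (0.68 log units; beyond the scatter). Compound 4 is estimated at 3 10^-6 cm/s, with an expected range of 0.9 10^-6 cm/s to 10 10^-6 cm/s.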

Compound 4, apparent permeability: 2.3 10^-6 cm/s
The estimate for compound 4 lay 1.3-fold (0.12 log units) above the measured number; the range from low to high includes it.
By their numbers in this assay, from the lowest: compound 2; then compounds 4 and 1 (each within the scatter of the next); then compound 3.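

In this assay, going by these compounds alone, 2-fluorophenyl in place of (pyridin-2-yl)methyl gives a 3.7-fold higher number from compound 2 to compound 4 (0.57 log units; beyond the scatter), the first step that changes one place only, so the read-out responds to a change at this saturated chain carbon. The change swaps a ring nitrogen and its hydrogen-bond acceptor for a fluorine, with the heavy-atom count unchanged. No measurement here bears on the reason for this step.

Still open, from the compounds shown here alone, is how the step divides between losing the ring nitrogen and gaining the fluorine. Unsubstituted phenyl or (2-fluorophenyl)methyl at this place would help separate the two.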